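Swapping a thiophene for a thioanisole on a sulfone-bearing enone

The source may hold more compounds than are shown below. What is called first, only, known or untested is meant among the compounds shown, and "the series" means these compounds.

Compound 2 `Cc1ccc(CS/C(=C/c2sccc2C)C(=O)c2ccc(Cl)cc2)cc1` and compound 1 `CSc1ccc(/C=C(/SCc2ccc(C)cc2)C(=O)c2ccc(Cl)cc2)cc1` share a core and differ by one change, (4-(methylsulfanyl)phenyl in place of 3-methylthiophen-2-yl on a double-bonded chain carbon bound to a double-bonded chain carbon). In a functional assay on DU-145 cells (Homo sapiens) for inhibition, read by trypan blue exclusion, with a stated time of 96 h (on this read-out lower numbers stand for stronger inhibition of growth and higher numbers for weaker inhibition of growth), compound 2 gives 10000 nM, while compound 1 gives 25000 nM, so the change made a 2.5-fold higher number from compound 2 to compound 1 (0.40 log units; beyond the scatter). Compound 3 `Cc1ccsc1/C=C(\C(=O)c1ccc(Cl)cc1)S(=O)(=O)Cc1ccc(Cl)cc1` carries a different core, and the difference between the cores of compound 3 and compound 2 is not broken down here; in this assay compound 3 gives 25000 nM. Compound 4 `CSc1ccc(/C=C(\C(=O)c2ccc(Cl)cc2)S(=O)(=O)Cc2ccc(Cl)cc2)cc1` is related to compound 3 by the same change, (4-(methylsulfanyl)phenyl in place of 3-methylthiophen-2-yl on a double-bonded chain carbon bound to a double-bonded chain carbon), and awaits measurement in this assay. If that change acts as it did before, compound 4 is expected to show a 2.2-fold higher number from compound 3 to compound 4 (0.34 log units; beyond the scatter), resting on the step seen from compound 2 to compound 1, namely a 2.5-fold higher number from compound 2 to compound 1 (0.40 log units; beyond the scatter). Compound 4 is therefore estimated at 55000 nM, with a plausible range from 20000 nM to 150000 nM.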

Compound 4, concentration for 50% growth inhibition: 10000 nM
Compound 4: the middle estimate sits 5.5-fold (0.74 log units) above what was measured; measured number outside the range, below it.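

In this assay, putting 4-(methylsulfanyl)phenyl in place of 3-methylthiophen-2-yl gave a 2.5-fold lower number from compound 3 to compound 4 (0.40 log units; beyond the scatter), meaning stronger growth inhibition on this core. The same change weakened growth inhibition on the other core, so neither its size nor its direction carried over from one core to the other: the same change on two cores in this assay, a 2.5-fold higher number (0.40 log units; beyond the scatter) from compound 2 to compound 1 and a 2.5-fold lower number (0.40 log units; beyond the scatter) from compound 3 to compound 4, 6.3-fold (0.80 log units) apart, beyond the scatter of two such steps

Going by these compounds alone, with only one pair on each core, this does not show which difference between the cores matters, or how the change would behave on a third core. The compounds shown carry only these two groups at this place. On these data alone, it remains open how a plain phenyl or a 4-aminophenyl there would behave on either core.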